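Compound 3 and the tail exchange on the shared core

A few compounds are considered here, and "the series" means these few. Any claim that something is new, unique, unknown or untested is made for them only; others in the source may bear on it.

Compound 1 `Cc1nc(NCCNC(=O)C2CC2)nc2ccc(NC(=O)/C=C/c3ccc(OC(F)(F)F)cc3)cc12` stands lowest of the two compounds measured: in an ADME assay on microsomes from liver (Mus musculus) for metabolic stability, with a stated time of 30 min (a lower number here means that less of the compound is left, a higher number that more of the compound is left), compound 1 gives 38%, whereas compound 2 `Cc1nc(NCCCNS(C)(=O)=O)nc2ccc(NC(=O)/C=C/c3ccc(OC(F)(F)F)cc3)cc12` gives 58%. Within the data shown here, the one measured step, a number 20 percentage points higher from compound 1 to compound 2 (beyond the scatter), exchanged only the tail on a saturated chain carbon. Compound 3 `Cc1nc(N2CCC(N3CCCC3=O)CC2)nc2ccc(NC(=O)/C=C/c3ccc(OC(F)(F)F)cc3)cc12` differs from compound 1 by 4-(2-oxopyrrolidin-1-yl)piperidin-1-yl in place of (2-((cyclopropylcarbonyl)amino)ethyl)amino on an aromatic carbon. Among the measured compounds shown here, no measured step covers this exchange, so the single tail step gives weak guidance and a change of any size is uncertain. A step of a number 7 percentage points higher from compound 1 to compound 3 (within the scatter) is expected, within the scatter. Compound 3 is estimated at 45%, with a range from 25% to 65%.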

Compound 3, percent of the compound remaining: 85%
The estimate for compound 3 lay 40 percentage points below the measured number; measured number above the stated range.
By their numbers in this assay, from the lowest: compound 1; then compound 2; then compound 3.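

In this assay, exchanging the group on the aromatic carbon between two ring nitrogen atoms for 4-(2-oxopyrrolidin-1-yl)piperidin-1-yl gives a number 47 percentage points higher from compound 1 to compound 3 (beyond the scatter) and a number 27 percentage points higher from compound 2 to compound 3 (beyond the scatter), so this position responds beyond the scatter against both open-chain tails. Here, a chain with 2 hydrogen-bond donors gives way to two non-aromatic rings with 0 hydrogen-bond donors, all in one exchange. Nothing at hand gives a reason for these steps.

Which part of the new group accounts for the steps remains open. A plain piperidin-1-yl or a piperidine bearing a 4-amino group would separate the piperidine ring from the 2-oxopyrrolidin-1-yl group.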